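The source may hold more compounds than are shown below. What is called first, only, known or untested is meant among the compounds shown, and "the series" means these compounds.

Working notes on a set of ethers sharing an amino-methoxy side chain. Compound 1 `CN1CCC[C@H]1COc1ccncc1` gives 7910 nM in an assay for binding affinity to Neuronal acetylcholine receptor; alpha4/beta2 (Rattus norvegicus); on this read-out lower numbers stand for stronger inhibition and higher numbers for weaker inhibition. Compound 2 `CN1CCC[C@H]1COc1cncnc1` gives 2.39 nM in this assay. Compound 3 `CN1CC[C@H]1COc1ccc(Cl)nn1` gives 63.8 nM in this assay, which places it second highest of the three numbers: compound 2 sits far lower and compound 1 far higher, both differences beyond the scatter.

The step from compound 3 to compound 4 `Clc1ccc(OC[C@@H]2CCN2)nn1` is hydrogen in place of methyl on an amine nitrogen in a ring. Within the data shown here, no measured pair shows this change here, so its size is not known from the series. Within this assay the step from compound 3 to compound 4 is expected to move the number modestly downward, estimated as a 3.2-fold lower number from compound 3 to compound 4 (0.50 log units; beyond the scatter), and compound 4 is expected to give 20 nM in this assay, in the range 5 nM to 80 nM.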

Compound 4, inhibition constant: 15.4 nM
Compound 4: the middle estimate sits 1.3-fold (0.11 log units) above what was measured, within the range that was stated.
By their numbers in this assay, from the lowest: compound 2; then compound 4; then compound 3; then compound 1.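

Among these compounds, this is the first measured pair, and it puts a size on the change: in this assay, hydrogen in place of methyl on the amine nitrogen of the four-membered ring gives a 4.1-fold lower number from compound 3 to compound 4 (0.62 log units; beyond the scatter), a modest step beyond the scatter. The methyl group is therefore not needed on this nitrogen to keep a low number while the rest of compound 3 stays unchanged. Nothing measured here gives a reason for the step. As far as these compounds go, whether the same change carries over to the core of compound 1 or compound 2 stays open. From the compounds shown here alone, how an ethyl group or a longer chain on this nitrogen would read also stays open.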